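Replacing the selenium group of compound 3 with bromo

This account rests on a few compounds, and the source may have more. Where it says the series, first, only, none or still open, it means among the compounds named here.

Measured so far in a functional assay on HCT-116 cells (Homo sapiens) for inhibition, read by MTT assay, with a stated time of 48 h; a lower number here means a stronger inhibitor, a higher number a weaker inhibitor:
- compound 1 `C#CC(=O)N(Cc1ccc(OC)c(O)c1)c1cc(OC)c(OC)c(OC)c1` gives 310 nM
- compound 2 `COc1ccc(CN(C(=O)CCCl)c2cc(OC)c(OC)c(OC)c2)cc1O` gives 150 nM
- compound 3 `COc1ccc(CN(C(=O)C[Se]C#N)c2cc(OC)c(OC)c(OC)c2)cc1O` gives 310 nM

Compound 3 shares its reading with compound 1, and the two hold the highest number of the three. Between them, no change at the digits printed from compound 1 to compound 3 (within the scatter). Compound 2 stands apart, with a 2.1-fold lower number from compound 1 to compound 2 (0.32 log units; beyond the scatter) and a 2.1-fold higher number from compound 2 to compound 3 (0.32 log units; beyond the scatter), both modest.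

Compound 4 `COc1ccc(CN(C(=O)CBr)c2cc(OC)c(OC)c(OC)c2)cc1O` is still unmeasured. The change is one bromine atom in place of a group of 3 heavy atoms (1 carbon, 1 nitrogen, 1 selenium; no ring), on a saturated chain carbon bound to a carbonyl carbon, on a saturated chain carbon bound to a carbonyl carbon. For the measured compounds named here, the most relevant evidence is a 2.1-fold higher number from compound 2 to compound 3 (0.32 log units; beyond the scatter), the only measured step that exchanges the selenium-bearing group for a chlorine-bearing one. Read in reverse, it suggests that a halogen-bearing group could return the number towards compound 2 at 150 nM, though this rests on one compound. A modest move in this assay is therefore expected, towards a lower number. The expected step is a 2.1-fold lower number from compound 3 to compound 4 (0.32 log units; beyond the scatter) as estimated here. For compound 4 the estimate is 150 nM, with an expected range from 50 nM to 400 nM.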

Compound 4, half-maximal inhibitory concentration: 68 nM
Compound 4: middle estimate off by 2.2-fold (0.34 log units), on the high side; the measured number falls inside the stated range.
By their numbers in this assay, from the lowest: compound 4; then compound 2; then compounds 1 and 3 (each within the scatter of the next).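

In this assay, bromo on the saturated chain carbon bound to a carbonyl carbon gives a clear gain over the selenium-bearing group, with a 4.6-fold lower number from compound 3 to compound 4 (0.66 log units; beyond the scatter), and a matching gain over the ethynyl compound, with a 4.6-fold lower number from compound 1 to compound 4 (0.66 log units; beyond the scatter). The halogen-bearing groups at this place also read apart, with a 2.2-fold lower number from compound 2 to compound 4 (0.34 log units; beyond the scatter), so the earlier gain of compound 2 is not the limit of the series. All three steps lie beyond the scatter, which sets compound 4 as the strongest inhibitor of the four, but nothing shown accounts for this order.

On these data alone, whether the gain is specific to bromo remains open: an iodo group, a fluoro group, an amine or a longer chain on this carbon would test how far it extends. All readings come from this assay, so whether the order holds in another cell line is also unresolved.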